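Removing the para propyl from an anilino quinone core

The source may hold more compounds than are shown below. What is called first, only, known or untested is meant among the compounds shown, and "the series" means these compounds.

The compounds share a tricyclic quinone core carrying an amino substituent on a double-bonded ring carbon. Compound 1, `CCCc1ccc(NC2=CC(=O)c3nc4n(c3C2=O)[C@H]2OC[C@@H](O)[C@H]2OC4)cc1`, is tested in a functional assay on HeLa cells (Homo sapiens) for inhibition, read by sulforhodamine B assay (a higher number here means a weaker inhibitor, a lower number a stronger inhibitor), where compound 1 gives 4990 nM. Among the two numbers shown it is the lowest, but its nearest neighbour, compound 2, `O=C1C(Nc2ccc(Br)cc2)=CC(=O)c2c1nc1n2[C@H]2OC[C@@H](O)[C@H]2OC1`, gives 5220 nM in this assay, a value within the scatter of compound 1, so the two cannot be ordered. Compound 3, `O=C1C(N2CCCCC2)=CC(=O)c2c1nc1n2[C@H]2OC[C@@H](O)[C@H]2OC1`, reaches only a limit in this assay, > 16000 nM, which is the limit of > 16000 nM in this assay, at which 1 of the 3 values shown sits. For the measured compounds named here, the one measured step, an at least 3.0-fold higher number from compound 2 to compound 3 (0.48 log units; beyond the scatter), shows that exchanging the arylamino group for a saturated amine costs potency.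

Compound 4, `O=C1C=C(Nc2ccccc2)C(=O)c2c1nc1n2[C@H]2OC[C@@H](O)[C@H]2OC1`, differs from compound 1 by hydrogen in place of propyl on an aromatic carbon. Going by the values given here, no measured step changes this position directly. What the data do show is that compound 1 and compound 2, which differ only in the group on that same aromatic carbon, give values within the scatter of each other, so the para substituent appears to matter little, while compound 3 shows that the arylamino group itself is what carries activity. Compound 4 keeps that arylamino group, so the step of a 1.3-fold higher number from compound 1 to compound 4 (0.11 log units; within the scatter) is expected to be small, if anything a slight weakening. Compound 4 is therefore estimated at 6500 nM in this assay, within 3000 nM to 14000 nM.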

Compound 4, half-maximal inhibitory concentration: 5620 nM
Beside the measured number, compound 4's estimate is 1.2-fold (0.06 log units) above it, and the stated range covers the measured number.
By their numbers in this assay, from the lowest: compounds 1, 2 and 4 (each within the scatter of the next). At a limit, above all of these: compound 3.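

In this assay, the step on removing the propyl is a 1.1-fold higher number from compound 1 to compound 4 (0.05 log units; within the scatter), so compound 4, with its plain phenyl, cannot be told apart from compound 1, with its 4-propylphenyl. For the compounds shown here, this is the first direct comparison with hydrogen on this aromatic carbon, and it shows that the propyl is not needed for a value of this size, at least for this one change on the shared core. Compound 3, which has no aromatic ring on the amino nitrogen, remains the only compound at a limit: the limit of > 16000 nM in this assay, at which 1 of the 4 values shown sits.

The compounds shown carry only propyl, bromine or hydrogen on this aromatic carbon, so it stays open whether a carboxylic acid, a dimethylamino group or a chain much longer than propyl would also leave the value in this range. As far as these compounds go, it also stays open whether compound 3 differs from compound 2 through the loss of the aromatic ring or of the amino hydrogen, which a cyclohexylamino or an N-methylanilino group would separate.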